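The source may hold more compounds than are shown below. What is called first, only, known or untested is meant among the compounds shown, and "the series" means these compounds.

Compound 1 `COc1ccc(C(=O)c2cccc(Cl)c2)cc1OC(=O)CCC(=O)OC[C@@H]1C=C[C@H](n2cc(C)c(=O)[nH]c2=O)O1`: 3210 nM
Compound 2 `COc1ccc(C(=O)c2ccccc2Cl)cc1OCC(=O)OC[C@@H]1C=C[C@H](n2cc(C)c(=O)[nH]c2=O)O1`: 40600 nM

Both compounds were tested in a functional assay on SMMC-7721 cells (Homo sapiens) for antiproliferative activity, read by MTT assay, with a stated time of 48 h; on this read-out higher numbers stand for weaker inhibition and lower numbers for stronger inhibition. Compound 1 holds the lowest number of the two; compound 2 gives a higher number, and the gap between them lies beyond the usual scatter. Compound 3 `COc1cc(OC)c(C(=O)c2ccc(OC)c(OC(=O)CCC(=O)OC[C@@H]3C=C[C@H](n4cc(C)c(=O)[nH]c4=O)O3)c2)cc1OC` has not yet been measured in this assay. It keeps the shared core of compound 1 and differs from it in one place: 2,4,5-trimethoxyphenyl in place of 3-chlorophenyl on a carbonyl carbon. For the measured compounds named here, no measured pair of compounds shows this same exchange, so the data give no direct guide to how large the resulting step might be or in which direction it should run. On that basis the step from compound 1 to compound 3 is expected to be modest, a 1.1-fold lower number from compound 1 to compound 3 (0.03 log units; within the scatter), with a real chance that it stays within the scatter. Compound 3 is therefore estimated at 3000 nM, with a plausible range from 700 nM to 15000 nM.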

Compound 3, half-maximal inhibitory concentration: 2860 nM
Compound 3: middle estimate off by 1.0-fold (0.02 log units), on the high side; low and high end bracket the measured number.
By their numbers in this assay, from the lowest: compounds 3 and 1 (each within the scatter of the next); then compound 2.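

In this assay there is a 1.1-fold lower number from compound 1 to compound 3 (0.05 log units; within the scatter) when 2,4,5-trimethoxyphenyl takes the place of 3-chlorophenyl on a carbonyl carbon. For the compounds shown here, this is the first direct view of this position, and it shows that a chlorine-bearing ring can give way to a larger group, with 12 heavy atoms against 7 and 3 hydrogen-bond acceptors against 0, without a change beyond the scatter in this assay. Nothing measured here explains why two such different groups read alike.

The compounds shown leave open whether this position would accept a group of another kind, such as an amine or a carboxylic acid, equally well. Going by these compounds alone, they also leave open how a ring with only one methoxy group would read on the same carbonyl carbon.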